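Sulfonyl aryl variation on the shared piperidinyl-piperidine core

A few compounds are considered here, and "the series" means these few. Any claim that something is new, unique, unknown or untested is made for them only; others in the source may bear on it.

Values in a functional assay on DLD-1 cells (Homo sapiens) for antiproliferative activity, read by CellTiter-Glo, with a stated time of 72 h; a lower number here means a stronger inhibitor, a higher number a weaker inhibitor:
compound 1 `CC1CCN(C2CCN(S(=O)(=O)c3ccc(C#N)cc3)CC2)CC1` gives 2800 nM.
compound 2 `CC1CCN(C2CCN(S(=O)(=O)c3cccc(N)c3)CC2)CC1` gives 3400 nM.
compound 3 `CC1CCN(C2CCN(S(=O)(=O)c3nccn3C)CC2)CC1` gives > 5000 nM, which is a limit of the assay and not a number.

Compound 1 holds the lowest of the two numbers shown. Its nearest neighbour is compound 2, with a 1.2-fold higher number from compound 1 to compound 2 (0.08 log units; within the scatter). Compound 3 sits at the limit of > 5000 nM in this assay, at which 1 of the 3 values shown sits.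

The next compound, compound 4 `CC1CCN(C2CCN(S(=O)(=O)c3ccc(-c4ccccc4)cc3)CC2)CC1`, differs from compound 1 by phenyl in place of cyano on an aromatic carbon. The measured steps that bear on this are those that exchanged the group on the sulfonyl sulfur of the shared core: a 1.2-fold higher number from compound 1 to compound 2 (0.08 log units; within the scatter) and an at least 1.7-fold higher number from compound 1 to compound 3 (0.25 log units; that floor lies within the scatter). Both lie within the scatter, so exchanging the sulfonyl aryl group has so far not moved this assay beyond its noise. The entering phenyl is larger than either earlier replacement, so the range is kept wide. The expected step is a 1.1-fold lower number from compound 1 to compound 4 (0.05 log units; within the scatter), that is, none beyond the scatter. For compound 4 the estimate is 2500 nM, with a range from 800 nM to 8000 nM.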

Compound 4, half-maximal inhibitory concentration: 258 nM
Estimate against measurement, compound 4: 9.7-fold (0.99 log units) above; measured number outside the range, below it.
By their numbers in this assay, from the lowest: compound 4; then compounds 1 and 2 (each within the scatter of the next). At a limit, above all of these: compound 3.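

In this assay, phenyl in place of cyano on the aromatic carbon para to a large group gives an 11-fold lower number from compound 1 to compound 4 (1.04 log units; beyond the scatter), the only step shown that is printed as beyond the scatter. Among these compounds, the earlier exchanges of the whole group on the sulfonyl sulfur gave no step that could be read that way, so this result is the first sign that the assay responds to a change on this ring. The exchange removes a triple bond and a hydrogen-bond acceptor and adds a six-membered aromatic ring of carbon only, and nothing measured here separates these features or gives a cause for the step.

Open, going by these compounds, is whether a saturated ring such as cyclohexyl on the same carbon would match phenyl. Also open, on these data alone, is how an amine or a carboxylic acid on the entering phenyl would read in this assay.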